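Carbamoyl for Amino on the Aryl Ring of Compound 3

The source may report more compounds than this note shows. Statements on the series, on what has been measured and on what is new or still open speak of the compounds shown alone.

Measured compounds in an assay on isolated protein for inhibition of 11-beta-hydroxysteroid dehydrogenase type 2 (Homo sapiens); a lower number here means a stronger inhibitor, a higher number a weaker inhibitor:
compound 1 `CC(=O)Nc1ccc(-c2nnc(C3(c4ccc(Cl)cc4)CCC3)n2C)c(Cl)c1`: > 4000 nM
compound 2 `Cn1c(-c2ccc(C(N)=O)cc2C(N)=O)nnc1C1(c2ccc(Cl)cc2)CCC1`: > 4000 nM
compound 3 `Cn1c(-c2ccc(N)cc2Cl)nnc1C1(c2ccc(Cl)cc2)CCC1`: 2300 nM

Compound 1 gives only a limit of this assay, > 4000 nM. Compound 2 likewise gives only a limit, > 4000 nM. Going by the values given here, compound 3 is the single compound with a number, 2300 nM, so it is the only fixed point. Among the compounds with values here, the one measured step, an at least 1.7-fold lower number from compound 1 to compound 3 (0.24 log units; that floor lies within the scatter), shows that a larger group on the amino nitrogen pushes the value to the limit, and the limit of > 4000 nM in this assay, at which 2 of the 3 values shown sit, marks where compound 1 and compound 2 sit.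

Compound 4 `Cn1c(-c2ccc(C(N)=O)cc2Cl)nnc1C1(c2ccc(Cl)cc2)CCC1` differs from compound 3 by carbamoyl in place of amino on an aromatic carbon, meta to a chloro group and para to a large group. Both compounds carrying a group larger than amino at a comparable position, compound 1 and compound 2, gave limits, so the step to compound 4 is expected to run toward weaker inhibition, and the number may again be a limit. Compound 4 is therefore estimated at 5500 nM, between 2000 nM and 15000 nM, meaning an expected step of a 2.4-fold higher number from compound 3 to compound 4 (0.38 log units; beyond the scatter).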

Compound 4, half-maximal inhibitory concentration: > 4000 nM
Compound 4 ended at the assay's limit (the forecaster's own chance of this, stated with the estimate: 60%); the middle value is on the limit's open side.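

With an at least 1.7-fold higher number from compound 3 to compound 4 (0.24 log units; that floor lies within the scatter) the carbamoyl group shows that replacing the amino group outright, and not only carrying acetyl on its nitrogen as compound 1 does, also ends at the limit of this assay and gives no number. The floor of that step lies within the scatter, so no real difference from compound 3 is established, and the steps from compound 1 and compound 2 to compound 4 cannot be read. Among the groups shown at this position, amino alone keeps a number, and the limit has become the common reading: the limit of > 4000 nM in this assay, at which 3 of the 4 values shown sit.

As far as these compounds go, how far compound 1, compound 2 and compound 4 lie beyond that limit remains open, so carbamoyl and acetamido cannot be ranked. Also open, from the compounds shown here alone, is whether hydroxyl, methylamino or a carboxylic acid on this carbon would give a number, as amino does.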